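Branching the hydroxyalkyl chain of compound 1

A few compounds are considered here, and "the series" means these few. Any claim that something is new, unique, unknown or untested is made for them only; others in the source may bear on it.

Compound 1 `COc1cc(Cc2nc3c(N)ncnc3n2CCCO)cc(OC)c1OC` gives 92700000 nM in a functional assay on MCF7 cells (Homo sapiens) for cytotoxicity (on this read-out higher numbers stand for an effect only at larger amounts of compound and lower numbers for an effect already at smaller amounts), the highest of the three numbers. Compound 2 `COc1cc(Cc2nc3c(N)ncnc3n2CCCCO)cc(OC)c1OC` gives 76900000 nM and compound 3 `COc1cc(Cc2nc3c(N)ncnc3n2CCCCCO)cc(OC)c1OC` gives 84900000 nM; the steps of a 1.2-fold lower number from compound 1 to compound 2 (0.08 log units; within the scatter) and a 1.1-fold lower number from compound 1 to compound 3 (0.04 log units; within the scatter) stay within the scatter, as does a 1.1-fold higher number from compound 2 to compound 3 (0.04 log units; within the scatter). Compound 4 `CCC(CO)CCn1c(Cc2cc(OC)c(OC)c(OC)c2)nc2c(N)ncnc21` differs from compound 1 by 1-(hydroxymethyl)propyl in place of hydroxymethyl on a saturated chain carbon, two bonds along the chain from an aromatic nitrogen. The measured steps bear on this change only in that lengthening the chain left this assay unchanged; a branched chain has not been tested. Because the steps of a 1.2-fold lower number from compound 1 to compound 2 (0.08 log units; within the scatter) and a 1.1-fold lower number from compound 1 to compound 3 (0.04 log units; within the scatter) remained within the scatter, no step beyond the scatter is expected, a 1.1-fold lower number from compound 1 to compound 4 (0.04 log units; within the scatter). Compound 4 is therefore estimated at 85000000 nM, with a range from 40000000 nM to 180000000 nM.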

Compound 4, half-maximal effective concentration: 19200000 nM
Compound 4: the middle estimate sits 4.4-fold (0.65 log units) above what was measured; measured number outside the range, below it.
By their numbers in this assay, from the lowest: compound 4; then compounds 2, 3 and 1 (each within the scatter of the next).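

In this assay, branching moves the number where lengthening the straight chain did not: ethyl in place of hydrogen on a saturated chain carbon bound to two saturated chain carbons gives a 4.0-fold lower number from compound 2 to compound 4 (0.60 log units; beyond the scatter) and the comparisons with the unbranched chains give a 4.8-fold lower number from compound 1 to compound 4 (0.68 log units; beyond the scatter) and a 4.4-fold lower number from compound 3 to compound 4 (0.65 log units; beyond the scatter) with all three beyond the scatter. This chain carbon therefore responds to an added ethyl, while chain length alone, across compounds 1, 2 and 3, does not. Nothing available explains this shift.

The compounds shown leave open whether methyl or a longer branch on this carbon would give a similar step. They also leave open how an amine or a carboxylic acid in place of the hydroxy would read.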